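A few compounds are considered here, and "the series" means these few. Any claim that something is new, unique, unknown or untested is made for them only; others in the source may bear on it.

Three compounds have been measured in a functional assay on NCI-H1975 cells (Homo sapiens) for inhibition, read by MTT assay, with a stated time of 72 h; on this read-out lower numbers stand for stronger inhibition and higher numbers for weaker inhibition:

compound 1 `CCc1cccc(NC(=O)CSc2nc(Nc3ccccc3)c3ccccc3n2)c1` gives 12000 nM
compound 2 `O=C(CSc1nc(Nc2ccccc2)c2ccccc2n1)Nc1ccc(F)cc1` gives 16500 nM
compound 3 `O=C(CSc1nc(Nc2ccccc2)c2ccccc2n1)Nc1ccc(Br)cc1` gives 10600 nM

Compound 3 shows the lowest of these three numbers, but the gaps to its neighbours are small: a 1.1-fold lower number from compound 1 to compound 3 (0.05 log units; within the scatter) and a 1.6-fold lower number from compound 2 to compound 3 (0.19 log units; within the scatter) both lie within the usual scatter, so the three compounds cannot be told apart on this read-out.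

Compound 4 `CCc1ccc(NC(=O)CSc2nc(Nc3ccccc3)c3ccccc3n2)cc1` has not yet been measured. It differs from compound 3 in one place: ethyl in place of bromo on an aromatic carbon. Among the compounds with values here, two measured steps bear on this change. The step of a 1.1-fold lower number from compound 1 to compound 3 (0.05 log units; within the scatter) swaps an ethyl-bearing ring for a bromo-bearing ring, and the step of a 1.6-fold lower number from compound 2 to compound 3 (0.19 log units; within the scatter) swaps one halogen for another on the same position; neither moved the number beyond the scatter. Replacing bromo with ethyl is therefore expected to leave the number in this assay roughly where it is, with no step beyond the scatter in either direction.

For compound 4 the estimated value is 11000 nM, with a range from 5000 nM to 25000 nM. The expected step of a 1.0-fold higher number from compound 3 to compound 4 (0.02 log units; within the scatter) is thus within the scatter.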

Compound 4, half-maximal inhibitory concentration: 9910 nM
Beside the measured number, compound 4's estimate is 1.1-fold (0.05 log units) above it; measured number inside the range.
By their numbers in this assay, from the lowest: compounds 4, 3, 1 and 2 (each within the scatter of the next).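

In this assay, ethyl in place of bromo (a 1.1-fold lower number from compound 3 to compound 4 (0.03 log units; within the scatter)) and ethyl in place of fluoro (a 1.7-fold lower number from compound 2 to compound 4 (0.22 log units; within the scatter)) both stay within the scatter, so on this ring a small carbon group cannot be told apart from either halogen. Moving the ethyl group itself, with 4-ethylphenyl in place of 3-ethylphenyl (a 1.2-fold lower number from compound 1 to compound 4 (0.08 log units; within the scatter)), also stays within the scatter, so these two ring positions for ethyl cannot be told apart on this read-out. No evidence is available on what lies behind this flat picture.

Going by these compounds, only halogens and ethyl appear on this ring, so it remains open whether an amine, a carboxylic acid or a longer chain such as hexyl would move the number beyond the scatter. On these data alone, all four compounds also share the same core, so the effect of changes there remains unknown.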